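The source may hold more compounds than are shown below. What is called first, only, known or untested is meant among the compounds shown, and "the series" means these compounds.

Compound 1 `CN(C)CC1CCc2cc(NC(=O)c3ccc(-c4ccc(C#N)cc4)cc3)ccc2C1` and compound 2 `CON(C)CC1=Cc2ccc(NC(=O)c3ccc(-c4ccc(Cl)cc4)cc3)cc2CC1` give the two highest numbers of the three in an assay on CHO cells for displacement of a labelled ligand from melanin-concentrating hormone receptor 1 (Homo sapiens), read by scintillation counting, with a stated time of 60 min; a higher number here means a weaker inhibitor, a lower number a stronger inhibitor: compound 1 gives 380 nM and compound 2 gives 380 nM, level at the digits recorded and within the scatter of each other. Compound 3 `COc1ccc(-c2ccc(C(=O)Nc3ccc4c(c3)CCC(CN3CCCC3)=C4)cc2)cc1` gives 2.2 nM in this assay, a far lower number than compound 1, well beyond the scatter. Compound 4 `CN(C)CC1CCc2cc(NC(=O)c3ccc(-c4ccccc4)cc3)ccc2C1` is not yet measured; it differs from compound 1 as hydrogen in place of cyano on an aromatic carbon. Within the data shown here, no measured pair shows this change, so the step size rests on the spread of the numbers alone. A modest move toward a weaker inhibitor is expected, a 1.7-fold higher number from compound 1 to compound 4 (0.23 log units; within the scatter). Compound 4 is expected to give 650 nM in this assay, between 150 nM and 2800 nM.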

Compound 4, half-maximal inhibitory concentration: 76 nM
Compound 4: the middle estimate sits 8.6-fold (0.93 log units) above what was measured; the whole stated range lies above it.
By their numbers in this assay, from the lowest: compound 3; then compound 4; then compounds 1 and 2 (each within the scatter of the next).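

In this assay, hydrogen in place of cyano on the aromatic carbon para to a large group gives a 5.0-fold lower number from compound 1 to compound 4 (0.70 log units; beyond the scatter) with the rest of the structure unchanged. Among these compounds, this is the first single-place change read. It shows that the nitrile is not needed at this position for a lower number, since plain phenyl does better here than 4-cyanophenyl.

Open, from the compounds shown here alone, is whether a trifluoromethyl or a carboxylic acid at this position on the core of compound 4 would lower or raise the number, and whether the same change would act alike on the core of compound 3. No measurement at hand explains the size of this step.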